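The compounds below may be only part of what the source reports. "The series", "measured", "known", "first", "only" and "open" are said of these compounds alone.

Measured compounds:
Compound 1 `Cc1cc(O)c(C2=NN(c3ccc(S(N)(=O)=O)cc3)C(c3ccccc3O)C2)cc1Cl`: 4210 nM
Compound 2 `Cc1cc(O)c(C2=NN(c3ccc(S(N)(=O)=O)cc3)C(c3ccccc3Cl)C2)cc1Cl`: 4520 nM

In a functional assay on 786-0 cells (Homo sapiens) for antiproliferative activity, with a stated time of 48 h (a higher number here means a weaker inhibitor of growth, a lower number a stronger inhibitor of growth), compound 2 holds the higher of the two numbers, with compound 1 nearest; the step of a 1.1-fold higher number from compound 1 to compound 2 (0.03 log units; within the scatter) is within the scatter. Compound 3 `Cc1cc(O)c(C2=NN(c3ccc(S(N)(=O)=O)cc3)C(/C=C/c3ccccc3)C2)cc1Cl` differs from compound 2 by 2-phenylethenyl in place of 2-chlorophenyl on a saturated ring carbon. Going by the values given here, the single measured step concerns a different exchange at that carbon, so no step directly bears on this change. The expectation for compound 3 is therefore no step beyond the scatter, with the step of a 1.0-fold lower number from compound 2 to compound 3 (0.00 log units; within the scatter) carrying wide uncertainty. Compound 3 is estimated at 4500 nM, range 1500 nM to 13000 nM.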

Compound 3, concentration for total growth inhibition: 12500 nM
The estimate for compound 3 lay 2.8-fold (0.44 log units) below the measured number; low and high end bracket the measured number.
By their numbers in this assay, from the lowest: compounds 1 and 2 (each within the scatter of the next); then compound 3.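

In this assay, the saturated ring carbon proves responsive: exchanging the aryl group for 2-phenylethenyl gives a 2.8-fold higher number from compound 2 to compound 3 (0.44 log units; beyond the scatter) and a 3.0-fold higher number from compound 1 to compound 3 (0.47 log units; beyond the scatter), whereas the chloro-for-hydroxy exchange on that aryl group stayed within the scatter. The number at this carbon therefore depends on more than that exchange on the aryl ring. Nothing available explains the step.

Open, on these data alone, is whether the step follows the double bond itself, which a 2-phenylethyl group at this carbon would test. Also open, as far as these compounds go, is how a small group such as methyl would behave there.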